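Mirror Image of a Bromo-Methoxypyridine Diazabicycle

A few compounds are considered here, and "the series" means these few. Any claim that something is new, unique, unknown or untested is made for them only; others in the source may bear on it.

Compound 1 `Brc1cc(N2CC[C@@H]3CN[C@@H]3C2)cnc1Br`: 76 nM
Compound 2 `COc1cncc(N2CC[C@@H]3CN[C@@H]3C2)c1`: 2700 nM
Compound 3 `COc1cc(N2CC[C@H]3CN[C@H]3C2)cnc1Br`: 21 nM

In a functional assay on HEK293 cells for agonist activity at Neuronal acetylcholine receptor; alpha4/beta2 (Homo sapiens), read by FLIPR (on this read-out higher numbers stand for an effect only at larger amounts of compound and lower numbers for an effect already at smaller amounts), compound 3 has the lowest number of the three measured compounds; compound 1 stands nearest, and the gap to compound 2 is far larger, both beyond the scatter. Compound 4 `COc1cc(N2CC[C@@H]3CN[C@@H]3C2)cnc1Br` is the mirror image of compound 3: the two compounds have the same atoms and bonds and differ only in configuration as drawn: 2 of 2 stereo elements differ (all stereocentres are inverted: mirror images); a stereocentre at a saturated ring carbon is drawn S in compound 3 and R in compound 4; a stereocentre at a saturated ring carbon is drawn R in compound 3 and S in compound 4. No measured pair differs only in configuration, so nothing shown tells how large such a step is in this assay. Mirror images can differ markedly, and compound 3 already holds the lowest number, so compound 4 is expected to show a higher number, with a step of a 2.9-fold higher number from compound 3 to compound 4 (0.46 log units; beyond the scatter). Compound 4 is therefore estimated at 60 nM, within a range of 12 nM to 400 nM.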

Compound 4, half-maximal effective concentration: 360 nM
Estimate against measurement, compound 4: 6.0-fold (0.78 log units) below, within the range that was stated.
By their numbers in this assay, from the lowest: compound 3; then compound 1; then compound 4; then compound 2.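

Inverting both stereocentres gives a 17-fold higher number from compound 3 to compound 4 (1.23 log units; beyond the scatter), the first measure of what configuration alone does in this assay, and the whole step can be assigned to it: the fact that compounds 3 and 4 differ only in the configuration as drawn.
Within the configuration of compound 4, the substituent steps are smaller: bromo in place of hydrogen on an aromatic carbon gives a 7.5-fold lower number from compound 2 to compound 4 (0.88 log units; beyond the scatter), and methoxy in place of bromo on an aromatic carbon gives a 4.7-fold higher number from compound 1 to compound 4 (0.68 log units; beyond the scatter), both modest.

From the compounds shown here alone, whether a configuration step of this size would also appear for the mirror images of compound 1 and compound 2 stays open. So does how ethoxy in place of methoxy, or chloro in place of bromo, would read.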